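The source may hold more compounds than are shown below. What is called first, only, known or untested is meant among the compounds shown, and "the series" means these compounds.

In a functional assay on MCF7 cells (Homo sapiens) for cytotoxicity, read by MTT assay, with a stated time of 48 h (on this read-out lower numbers stand for stronger inhibition and higher numbers for weaker inhibition), three compounds sharing one core have been measured so far. Compound 1 `Cc1ccccc1-c1nnc(SCCn2c([N+](=O)[O-])cnc2C)o1` gives 15800 nM, compound 2 `COc1ccccc1-c1nnc(SCCn2c([N+](=O)[O-])cnc2C)o1` gives 10800 nM, and compound 3 `Cc1ncc([N+](=O)[O-])n1CCSc1nnc(-c2ccccc2F)o1` gives 20500 nM. Compound 3 therefore stands within the scatter of both other compounds, and the three numbers cannot be ranked with confidence.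

Compound 4 `Cc1ncc([N+](=O)[O-])n1CCSc1nnc(-c2ccc(F)cc2)o1`, which has not yet been measured, contains the same atoms as compound 3, joined differently: 4-fluorophenyl in place of 2-fluorophenyl on an aromatic carbon. In words, it carries 4-fluorophenyl in place of 2-fluorophenyl on an aromatic carbon.

Within the data shown here, no measured pair shows this exact exchange, so the evidence is indirect. The closest comparison comes from the three exchanges among the methyl, methoxy and fluoro compounds: a 1.5-fold lower number from compound 1 to compound 2 (0.17 log units; within the scatter), a 1.3-fold higher number from compound 1 to compound 3 (0.11 log units; within the scatter) and a 1.9-fold higher number from compound 2 to compound 3 (0.28 log units; within the scatter). All three remain within the scatter, although none of them tests a fluoro group in a different place. On this limited basis, no step beyond the scatter is expected in this assay. The expected step is a 1.2-fold lower number from compound 3 to compound 4 (0.08 log units; within the scatter). The estimate for compound 4 is 17000 nM, with an expected range of 8000 nM to 36000 nM.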

Compound 4, half-maximal inhibitory concentration: 8100 nM
Compound 4: the middle estimate sits 2.1-fold (0.32 log units) above what was measured; the range from low to high includes it.
By their numbers in this assay, from the lowest: compounds 4, 2, 1 and 3 (each within the scatter of the next, the first and the last beyond it).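

Moving the fluorine while keeping the same atoms produces the first step in this series to pass beyond the scatter: in this assay there is a 2.5-fold lower number from compound 3 to compound 4 (0.40 log units; beyond the scatter), a modest change, so the arrangement of the aryl group at this place on the shared core can register in the read-out even though the earlier exchanges of methyl, methoxy and fluoro did not. The separation is limited to this one pair, since a 1.3-fold lower number from compound 2 to compound 4 (0.12 log units; within the scatter) and a 2.0-fold lower number from compound 1 to compound 4 (0.29 log units; within the scatter) both remain within the scatter, which leaves compound 4 unranked against compound 1 and compound 2 and shows that 4-fluorophenyl stands clearly apart only from 2-fluorophenyl. Nothing available here accounts for the difference between the two fluorophenyl compounds.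

The compounds shown leave open whether this step belongs to fluoro specifically or would also appear with 4-methylphenyl or 4-methoxyphenyl at the same place. They also leave open how a chloro group, an amine or a carboxylic acid on that phenyl ring would compare in this assay.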